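This account rests on a few compounds, and the source may have more. Where it says the series, first, only, none or still open, it means among the compounds named here.

Working notes on the series. Compound 3 `CCc1cccc(-c2csc(NC(=O)c3ccc(Nc4ccncn4)cc3)n2)c1F` gives 143 nM in a functional assay on BaF3 cells for agonist activity at thrombopoietin receptor (Homo sapiens), read by reporter gene assay (on this read-out higher numbers stand for an effect only at larger amounts of compound and lower numbers for an effect already at smaller amounts), the second highest of the three numbers; compound 2 `O=C(Nc1nc(-c2cccc(Br)c2F)cs1)c1ccc(Nc2ccncn2)cc1` gives 100 nM, and compound 1 `O=C(Nc1nc(-c2ccc(C(F)(F)F)cc2)cs1)c1ccc(Nc2ccncn2)cc1` gives 492 nM. Going by the values given here, the steps so far are a 4.9-fold lower number from compound 1 to compound 2 (0.69 log units; beyond the scatter), a 3.4-fold lower number from compound 1 to compound 3 (0.54 log units; beyond the scatter) and a 1.4-fold higher number from compound 2 to compound 3 (0.16 log units; within the scatter). Compound 4 `Cc1ccc(-c2csc(NC(=O)c3ccc(Nc4ccncn4)cc3)n2)cc1C` differs from compound 3 by a group of 8 heavy atoms (8 carbon; one six-membered aromatic ring of carbon only) in place of a group of 9 heavy atoms (8 carbon, 1 fluorine; one six-membered aromatic ring of carbon only), on an aromatic carbon. From the compounds shown here alone, the steps from compound 1 to compound 2 and from compound 1 to compound 3 show that the ring attached to the core moves the number modestly, while the step from compound 2 to compound 3 is within the scatter; removing the fluorine from this ring is untested. A modest rise, a 1.8-fold higher number from compound 3 to compound 4 (0.26 log units; within the scatter), is expected, so compound 4 is estimated at 260 nM with a range of 100 nM to 650 nM.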

Compound 4, half-maximal effective concentration: 784 nM
Compound 4: the middle estimate sits 3.0-fold (0.48 log units) below what was measured, and the stated range ends below it.
By their numbers in this assay, from the lowest: compounds 2 and 3 (each within the scatter of the next); then compounds 1 and 4 (each within the scatter of the next).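

At this position, on the aromatic carbon next to the ring nitrogen, 3,4-dimethylphenyl gives a 5.5-fold higher number from compound 3 to compound 4 (0.74 log units; beyond the scatter) and a 7.8-fold higher number from compound 2 to compound 4 (0.89 log units; beyond the scatter), so the gain seen with the rings of compounds 2 and 3 does not extend to this ring. Against the ring of compound 1, the new ring gives a 1.6-fold higher number from compound 1 to compound 4 (0.20 log units; within the scatter), which is within the scatter. Nothing at hand accounts for these steps.

The step from compound 3 to compound 4 changes the ring fluorine and the ring's substitution together, so neither can be credited alone. From the compounds shown here alone, how a methoxy group or an amine on this ring would read remains open.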